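The compounds below may be only part of what the source reports. "The series", "measured", "known", "first", "only" and "open" are said of these compounds alone.

In a functional assay on RAW264.7 cells (Mus musculus) for inhibition, read by Griess assay, with stated times of 3 h and 24 h (on this read-out higher numbers stand for weaker inhibition and lower numbers for stronger inhibition), compound 3 (`C=C1CC[C@H]2[C@@](C)(CC[C@@H](O)[C@@]2(C)NC=O)[C@@H]1/C=C/C1=CCOC1=O`) gives > 50000 nM as a limit of the assay and not a number. Compound 1 (`C=C1CC[C@H]2[C@@](C)(CCC(=O)N[C@@]2(C)CO)[C@@H]1/C=C/C1=CCOC1=O`) gives > 50000 nM as a limit too. Compound 2 (`C=C1CC[C@H]2[C@@](C)(CCC(=O)N[C@@]2(C)COC(=O)c2ccc([N+](=O)[O-])cc2)[C@@H]1/C=C/C1=CCOC1=O`) gives 33500 nM as a measured number. Compound 4 (`C=C1CC[C@H]2[C@@](C)(CC[C@@H](OC(=O)CNC)[C@@]2(C)NC=O)[C@@H]1/C=C/C1=CCOC1=O`) differs from compound 3 by ((methylamino)methyl)carbonyl in place of hydrogen on an oxygen on a saturated carbon. Going by the values given here, the one measured step of this kind, with (4-nitrophenyl)carbonyl entering, is an at least 1.4-fold lower number from compound 1 to compound 2 (0.17 log units; that floor lies within the scatter) and stays within the scatter, so in this assay only a small shift towards stronger inhibition is expected, perhaps none beyond the scatter. The estimated step is an at least 1.6-fold lower number from compound 3 to compound 4 (0.22 log units; that floor lies within the scatter) on present data. Compound 4 is estimated at 30000 nM with an expected range of 9000 nM to 70000 nM for now.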

Compound 4, half-maximal inhibitory concentration: > 50000 nM
Compound 4: no number, only a limit; the forecaster's own chance of this, stated with the estimate: 40%; middle value at least 1.6-fold (0.22 log units) from the limit.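

In this assay no step from compound 3 to compound 4 can be read, as both values are limits of the assay and not numbers: the limit of > 50000 nM in this assay, at which 3 of the 4 values shown sit.

The compounds shown leave open whether ((methylamino)methyl)carbonyl in place of hydrogen on this oxygen changes inhibition at all.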